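Replacing the sulfonamide hydrogen with cyclobutyl

The compounds below may be only part of what the source reports. "The series", "measured", "known", "first", "only" and "open" are said of these compounds alone.

In a physicochemical assay for lipophilicity, at pH 7.4 (on this read-out higher numbers stand for higher lipophilicity and lower numbers for lower lipophilicity), compound 1 `Cc1ccc(N(CC(C)C)S(=O)(=O)c2ccc3c(c2)C(=O)CC(C2CCOCC2)O3)c(C)c1` gives 4.28 as its reading. Compound 2 `Cc1ccc(NS(=O)(=O)c2ccc3c(c2)C(=O)CC(C2CCOCC2)O3)c(C)c1` gives 2.75 and stands as the lower of the two numbers, with the gap beyond the scatter.

Compound 3 `Cc1ccc(N(C2CCC2)S(=O)(=O)c2ccc3c(c2)C(=O)CC(C2CCOCC2)O3)c(C)c1` has the same core and carries cyclobutyl in place of hydrogen on a sulfonamide nitrogen and has no reading yet.

Among the compounds with values here, only one measured step bears on this change, and it is large and beyond the scatter: hydrogen in place of isobutyl on a sulfonamide nitrogen gave a number 1.53 log units lower from compound 1 to compound 2 (beyond the scatter) on this assay for that pair. Within the data shown here, the new change runs the opposite way, from hydrogen to a carbon-only group, so with compound 1 at 4.28 as the sole guide, a rise of similar size is expected. Among the measured compounds shown here, no cyclobutyl compound has a number yet, and one step is thin support, so the range stays wide.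

The estimated step is a number 1.35 log units higher from compound 2 to compound 3 (beyond the scatter) in the expected upward direction, beyond the scatter. Expected for compound 3 is 4.1 within a range of 3.6 to 4.5 on this estimate.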

Compound 3, distribution coefficient: 3.86
Compound 3: middle estimate off by 0.24 log units, on the high side; low and high end bracket the measured number.
By their numbers in this assay, from the lowest: compound 2; then compound 3; then compound 1.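

In this assay, cyclobutyl in place of hydrogen on a sulfonamide nitrogen gives a number 1.11 log units higher from compound 2 to compound 3 (beyond the scatter) on the shared core, so the higher reading seen with isobutyl at this nitrogen is also found with a second carbon-only group. The two groups do not give the same reading: cyclobutyl in place of isobutyl gives a number 0.42 log units lower from compound 1 to compound 3 (beyond the scatter) in this comparison, so the number at this position depends on which group is present and not only on the loss of the hydrogen. Nothing available explains the difference between cyclobutyl and isobutyl, and these readings alone cannot assign it to the ring, the branching or any other feature.

From the compounds shown here alone, with one ring and one branched chain on this nitrogen, it remains open how the reading would change with a longer straight chain, a cyclopentyl ring, or a chain ending in an amine or a carboxylic acid. Going by these compounds, it also remains open whether steps of this size would carry over to a core bearing a different group elsewhere, since all three compounds share one core.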